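Aryl swap on a shared core: from compound 2 to compound 3

This account rests on a few compounds, and the source may have more. Where it says the series, first, only, none or still open, it means among the compounds named here.

Of the compounds shown here, two have been measured so far. Compound 1 `C=CCn1c(=O)/c(=C\c2cc(Br)ccc2F)[nH]c(=O)/c1=C\c1ccccc1OC` gives 28100 nM in a functional assay on MCF7 cells (Homo sapiens) for cytotoxicity, read by CCK-8 assay, with a stated time of 72 h; a higher number here means a weaker inhibitor, a lower number a stronger inhibitor. Compound 2 `C=CCn1c(=O)/c(=C\c2cc(F)ccc2C)[nH]c(=O)/c1=C\c1ccccc1OC` gives 3100 nM in this assay, the lowest of the two numbers. For the measured compounds named here, the only step available, a 9.1-fold lower number from compound 1 to compound 2 (0.96 log units; beyond the scatter), shows that the substitution pattern on this aryl ring moves the number well beyond the scatter.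

Compound 3 `C=CCn1c(=O)/c(=C\c2cccc(C)c2)[nH]c(=O)/c1=C\c1ccccc1OC` is not yet measured. It differs from compound 2 in one place: 3-methylphenyl in place of 5-fluoro-2-methylphenyl on a double-bonded chain carbon bound to an aromatic carbon. Going by the values given here, no measured step covers this particular exchange, and the one step that exists, from compound 1 to compound 2, concerns a different pair of patterns on the same ring. Among the compounds with values here, it shows only that the ring tolerates little change without a sizable shift in either direction.

With nothing else to rest on, a shift beyond the scatter is expected for compound 3, but its direction is uncertain, so the step of a 2.1-fold higher number from compound 2 to compound 3 (0.32 log units; beyond the scatter) is an estimate of modest loss. The expected number for compound 3 is 6500 nM, with a range from 1500 nM to 28000 nM.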

Compound 3, half-maximal inhibitory concentration: 20700 nM
Compound 3: the middle estimate sits 3.2-fold (0.50 log units) below what was measured; the measured number falls inside the stated range.
By their numbers in this assay, from the lowest: compound 2; then compounds 3 and 1 (each within the scatter of the next).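

In this assay, placing 3-methylphenyl where 5-fluoro-2-methylphenyl stood on a double-bonded chain carbon bound to an aromatic carbon gives (a 6.7-fold higher number from compound 2 to compound 3 (0.82 log units; beyond the scatter)), so a second change to this ring also moves the number beyond the scatter, this time upward, which the earlier step could not show. The other new step (a 1.4-fold lower number from compound 1 to compound 3 (0.13 log units; within the scatter)) lies within the scatter, so 5-bromo-2-fluorophenyl and 3-methylphenyl, which carry different groups on the ring, cannot be told apart here, and only the 5-fluoro-2-methylphenyl group stands apart from both. No measured evidence on the reason for this separation is available.

The change from compound 2 to compound 3 removes the fluorine and alters where the methyl sits in a single exchange, so the share of each in the shift remains unresolved. The compounds shown also leave open how the number would respond at this position to an aryl ring bearing an amine or a carboxylic acid.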